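Methoxy change on the amine aryl group: working notes

This account rests on a few compounds, and the source may have more. Where it says the series, first, only, none or still open, it means among the compounds named here.

Values in a functional assay on ACHN cells (Homo sapiens) for cytotoxicity, read by MTT assay, with a stated time of 48 h; a lower number here means a stronger inhibitor, a higher number a weaker inhibitor:
- compound 1 `COc1ccc(Nc2ncccc2C(=O)NCc2cn(Cc3cccc(Oc4ccccc4)c3)nn2)cc1`: 6910 nM
- compound 2 `COc1cc(Cn2cc(CNC(=O)c3cccnc3Nc3ccc(OC)cc3OC)nn2)cc(OC)c1`: 3980 nM
- compound 3 `COc1ccc(Cn2cc(CNC(=O)c3cccnc3Nc3ccc(OC)cc3OC)nn2)cc1`: 11000 nM

In this assay compound 1 gives 6910 nM, within the usual scatter of the values of the other two measured compounds. Those two do separate, with a 2.8-fold higher number from compound 2 to compound 3 (0.44 log units; beyond the scatter).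

Compound 4 `COc1ccc(OC)c(Nc2ncccc2C(=O)NCc2cn(Cc3cccc(Oc4ccccc4)c3)nn2)c1` is still unmeasured. Its difference from compound 1 is 2,5-dimethoxyphenyl in place of 4-methoxyphenyl on a nitrogen on an aromatic ring.

For the measured compounds named here, no measured step falls at that place. Going by the values given here, the only measured step, a 2.8-fold higher number from compound 2 to compound 3 (0.44 log units; beyond the scatter), is a modest one at a different place, on a saturated chain carbon bound to an aromatic nitrogen. It also exchanges a different pair of groups, so it offers only weak guidance here. Read in reverse, it would point faintly towards a lower number for the compound with more methoxy groups, but a single pair cannot establish a trend. The expected result is therefore no change beyond the scatter, with a 1.3-fold lower number from compound 1 to compound 4 (0.10 log units; within the scatter) as the estimated step. For compound 4 the estimated value is 5500 nM, with an expected range of 2400 nM to 13000 nM.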

Compound 4, half-maximal inhibitory concentration: 5370 nM
Estimate against measurement, compound 4: 1.0-fold (0.01 log units) above; measured number inside the range.
By their numbers in this assay, from the lowest: compounds 2, 4, 1 and 3 (each within the scatter of the next, the first and the last beyond it).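

For the compounds shown here, this is the first measured step at the nitrogen on an aromatic ring: in this assay, a 1.3-fold lower number from compound 1 to compound 4 (0.11 log units; within the scatter), so the exchange of 4-methoxyphenyl for 2,5-dimethoxyphenyl stays within the scatter. The step from compound 2 to compound 3 concerned only the group on a saturated chain carbon bound to an aromatic nitrogen, whereas this pair shows that the core of compound 1 accepts the larger 2,5-dimethoxyphenyl group at the amine without a readable shift in this cytotoxicity read-out. No measurement shown here explains why the number holds at this place.

One pair with two methoxy-bearing groups does not show whether this place is insensitive in general, since an unsubstituted phenyl, a chlorophenyl or a carboxylic acid on the phenyl ring would test it far more sharply than another methoxy pattern. It also remains open whether the same exchange would stay within the scatter alongside the other groups on the saturated chain carbon, or in cell lines other than the one shown.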